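The source may hold more compounds than are shown below. What is called first, only, known or untested is meant among the compounds shown, and "the series" means these compounds.

Series notes

- compound 1 `CC(=O)OC1CC2(N3CCCCC3)CC(c3ccccc3)C1C(c1ccccc1)C2`: "not determined" (no result reported)
- compound 2 `O=C(CN1CCCC1)OC1CC2(N3CCCC3)CC(c3ccccc3)C1C(c1ccccc1)C2`: 42900 nM

In an ADME assay on L6 cells (Rattus norvegicus) for cytotoxicity, with a stated time of 72 h (on this read-out lower numbers stand for stronger inhibition and higher numbers for weaker inhibition), compound 2 gives 42900 nM. For the measured compounds named here, this is the only number so far, so it can be ranked against nothing, and compound 1 has no reported result. The next compound to read is compound 3 `O=C(CN1CCCC1)OC1CC2(N3CCCCC3)CC(c3ccccc3)C1C(c1ccccc1)C2`, which keeps the core and the ester side chain of compound 2 and changes one group: piperidin-1-yl in place of pyrrolidin-1-yl on a saturated ring carbon.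

Compound 1 also carries piperidin-1-yl, but without a number it offers no guide. Going by the values given here, no measured pair shows what this exchange does in this assay, so the expectation rests on the small size of the change alone. A large shift is not expected, and any movement would, if anything, be slightly towards stronger inhibition. The expected step of a 1.3-fold lower number from compound 2 to compound 3 (0.13 log units; within the scatter) stays within the scatter. For compound 3 the estimated value is 32000 nM, with an expected range of 12000 nM to 80000 nM.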

Compound 3, half-maximal inhibitory concentration: 16400 nM
Beside the measured number, compound 3's estimate is 2.0-fold (0.29 log units) above it; the measured number falls inside the stated range.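

In this assay, replacing pyrrolidin-1-yl with piperidin-1-yl on the saturated ring carbon gives a 2.6-fold lower number from compound 2 to compound 3 (0.42 log units; beyond the scatter), with the shared core and the ester side chain unchanged. For the compounds shown here, this is the first measured pair, and it shows that the read-out responds to a change at this position: a six-membered non-aromatic ring in place of a five-membered one moves the number beyond the scatter, although the step is only modest. Nothing available explains this shift, so the pair records the size and direction of the change but not its origin.

A single pair cannot show whether the number keeps falling as the ring grows or depends on something specific to piperidin-1-yl; azepan-1-yl, morpholin-4-yl or an open-chain dimethylamino group on the same carbon would separate these readings. As far as these compounds go, the contribution of the ester side chain also remains open, including whether the pyrrolidin-1-yl at its end could be exchanged for piperidin-1-yl or a longer chain with the same effect.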